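A few compounds are considered here, and "the series" means these few. Any claim that something is new, unique, unknown or untested is made for them only; others in the source may bear on it.

Measured so far in an ADME assay on MT4 cells (Homo sapiens) for cytotoxicity, read by MTT assay; on this read-out lower numbers stand for higher toxicity in this test and higher numbers for lower toxicity in this test:
- compound 1 `Cc1ccccc1NC(=O)CSc1nncnc1-c1cccc2ccccc12` gives 158000 nM
- compound 2 `O=C(CSc1nncnc1-c1cccc2ccccc12)Nc1ccccc1` gives 154000 nM
- compound 3 `Cc1ccc(NC(=O)CSc2nncnc2-c2cccc3ccccc23)c([N+](=O)[O-])c1` gives 147000 nM

Going by the values given here, compound 3 stands level with the other two within the scatter, and the series so far shows no spread in this assay at all. The next change is 2-chloropyridin-3-yl in place of 4-methyl-2-nitrophenyl on an amide-type nitrogen, which puts 2-chloropyridin-3-yl in place of 4-methyl-2-nitrophenyl on an amide-type nitrogen and gives compound 4 `O=C(CSc1nncnc1-c1cccc2ccccc12)Nc1cccnc1Cl` as the unmeasured member.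

Among the compounds with values here, three measured steps bear on this site: a 1.0-fold lower number from compound 2 to compound 3 (0.02 log units; within the scatter), a 1.1-fold lower number from compound 1 to compound 3 (0.03 log units; within the scatter) and a 1.0-fold lower number from compound 1 to compound 2 (0.01 log units; within the scatter). All three changed the same group and none moved the number. Within the data shown here, no measured compound carries a pyridine ring or a chlorine, so the evidence is indirect. No step beyond the scatter is therefore expected, and the expected move is a 1.1-fold lower number from compound 3 to compound 4 (0.02 log units; within the scatter) in this read-out. Compound 4 is estimated at 140000 nM with an expected range from 75000 nM to 260000 nM in this read-out.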

Compound 4, half-maximal cytotoxic concentration: 44000 nM
Compound 4: the middle estimate sits 3.2-fold (0.50 log units) above what was measured, and the stated range ends above it.
By their numbers in this assay, from the lowest: compound 4; then compounds 3, 2 and 1 (each within the scatter of the next).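

In this assay the group on the amide-type nitrogen is no longer silent: 2-chloropyridin-3-yl gives a 3.3-fold lower number from compound 3 to compound 4 (0.52 log units; beyond the scatter) and a 3.5-fold lower number from compound 2 to compound 4 (0.54 log units; beyond the scatter) and also a 3.6-fold lower number from compound 1 to compound 4 (0.56 log units; beyond the scatter) in the same direction, towards higher toxicity in this test. Phenyl, 2-methylphenyl and 4-methyl-2-nitrophenyl stand level with one another, so compound 4 alone shows that this position can shift the read-out beyond the scatter. No available measurement accounts for the shift.

The ring nitrogen and the chlorine enter together in compound 4, so the step cannot be assigned to either one. On these data alone, a plain pyridin-3-yl or a 2-chlorophenyl group on the same amide-type nitrogen would separate the two, and whether a carboxylic acid or an amine on that ring moves the number also stays open.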